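Chromane ureas and thioureas: cell growth inhibition notes

The source may hold more compounds than are shown below. What is called first, only, known or untested is meant among the compounds shown, and "the series" means these compounds.

The series shares a chromane core carrying a urea or thiourea on the ring carbon next to the oxygen-bearing ring junction, with variation in the halogen on the fused benzene ring and in the substituent on the distal nitrogen. In a functional assay on U-373MG ATCC cells (Homo sapiens) for inhibition, read by MTT assay, with a stated time of 72 h (on this read-out lower numbers stand for stronger inhibition and higher numbers for weaker inhibition), compound 1 `CC(C)NC(=O)NC1CC(C)(C)Oc2ccc(Cl)cc21` gives 62000 nM, the highest number of the three measured. Compound 3 `CC1(C)CC(NC(=S)Nc2ccccc2Cl)c2cc(Br)ccc2O1` gives 34000 nM in this assay, a number that sits within the scatter of compound 1. Compound 2 `CC1(C)CC(NC(=S)NCc2ccccc2)c2cc(F)ccc2O1` gives 27000 nM in this assay, and this gap from compound 1 lies beyond the scatter.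

Compound 4 `CC1(C)CC(NC(=O)Nc2ccc(Cl)cc2)c2cc(Cl)ccc2O1` has not yet been measured in this assay. It differs from compound 1 in one place: 4-chlorophenyl in place of isopropyl on an amide-type nitrogen. For the measured compounds named here, no measured pair in the set isolates this change, so the expectation rests on the values shown. Compound 3, which carries an aryl group on the distal nitrogen, gives a number in this assay within the scatter of compound 1, and compound 2 gives a somewhat lower number, so a small step downward, or none beyond the scatter, is expected for the change from compound 1 to compound 4, a 1.9-fold lower number from compound 1 to compound 4 (0.29 log units; within the scatter). Compound 4 is therefore estimated at 32000 nM in this assay, with a range from 11000 nM to 95000 nM.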

Compound 4, half-maximal inhibitory concentration: 19000 nM
Beside the measured number, compound 4's estimate is 1.7-fold (0.23 log units) above it; low and high end bracket the measured number.
By their numbers in this assay, from the lowest: compounds 4, 2, 3 and 1 (each within the scatter of the next, the first and the last beyond it).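

The isopropyl to 4-chlorophenyl change on the amide-type nitrogen gives the series its first comparison in one place in this assay, with the chlorine on the shared core and the urea carbonyl held constant: a 3.3-fold lower number from compound 1 to compound 4 (0.51 log units; beyond the scatter). The distal nitrogen of the urea is therefore a position where the group affects the read-out, and here the swap, which brings in a six-membered aromatic ring and a chlorine, moves the number towards stronger inhibition, with compound 4 at 19000 nM, though this remains a weak number on the scale of the assay. Nothing in the available data accounts for the size or direction of this step.

The step does not separate the aromatic ring from its chlorine, so a plain phenyl, a cyclohexyl or a 4-methoxyphenyl group on the same nitrogen would be needed to tell which part of the change carries it. Also open, on these data alone, is whether the step holds when the carbonyl is replaced by a thiocarbonyl, or when the chlorine on the shared core gives way to a bromine or a fluorine.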